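The source may report more compounds than this note shows. Statements on the series, on what has been measured and on what is new or still open speak of the compounds shown alone.

Compound 1 `Cc1cccc(C2CC(c3ccc(Oc4ccccc4)cc3)=NN2c2ccc(S(N)(=O)=O)cc2)c1` gives 8000 nM in an ADME assay on BHK-21 cells (Mesocricetus auratus) for cytotoxicity, read by MTT assay, with a stated time of 72 h (on this read-out lower numbers stand for higher toxicity in this test and higher numbers for lower toxicity in this test), and stands level with compound 2 `Cc1cccc(C2CC(c3ccc(OCc4ccccc4)cc3)=NN2c2ccc(S(N)(=O)=O)cc2)c1` at 8000 nM, the two together the lowest of the three numbers; the furthest from compound 1 is compound 3 `Cc1ccccc1C1CC(c2ccc(OCc3ccccc3)cc2)=NN1c1ccc(S(N)(=O)=O)cc1` at 20000 nM. Compound 4 `Cc1ccc(C2CC(c3ccc(Oc4ccccc4)cc3)=NN2c2ccc(S(N)(=O)=O)cc2)cc1` differs from compound 1 by 4-methylphenyl in place of 3-methylphenyl on a saturated ring carbon. The step of no change at the digits printed from compound 1 to compound 2 (within the scatter) touched the group on the oxygen and has little bearing here. The step of a 2.5-fold higher number from compound 2 to compound 3 (0.40 log units; beyond the scatter) exchanged one methylphenyl for another on the saturated ring carbon, the same kind of change as here, and gave a modest rise. A step of that size in either direction, or none beyond the scatter, is therefore expected for compound 4. Compound 4 is estimated at 10000 nM, between 4000 nM and 25000 nM. This estimate means an expected 1.3-fold higher number from compound 1 to compound 4 (0.10 log units; within the scatter).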

Compound 4, half-maximal cytotoxic concentration: 8000 nM
Compound 4: the middle estimate sits 1.3-fold (0.10 log units) above what was measured; the range from low to high includes it.
By their numbers in this assay, from the lowest: compounds 1, 2 and 4 (each within the scatter of the next); then compound 3.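

On the saturated ring carbon, 4-methylphenyl in place of 3-methylphenyl gives no change at the digits printed from compound 1 to compound 4 (within the scatter) in this assay and so leaves the number where it was. The earlier exchange at this position, a 2.5-fold higher number from compound 2 to compound 3 (0.40 log units; beyond the scatter) with 2-methylphenyl entering, had shown a modest rise, so an exchange of one methylphenyl for another here does not always move the number. No available evidence explains this contrast.

From the compounds shown here alone, it remains open whether 2-methylphenyl would also raise the number with phenyl rather than benzyl on the oxygen. Also open, going by these compounds, is what a 4-aminophenyl or 4-carboxyphenyl group would do at this carbon.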